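Compound 3 to compound 4: swapping the methylamino group

This account rests on a few compounds, and the source may have more. Where it says the series, first, only, none or still open, it means among the compounds named here.

Measured in a toxicity assay on CCRF-CEM cells (Homo sapiens) for cytotoxicity; a higher number here means that more compound is tolerated, a lower number that less compound is tolerated:
- compound 1 `CCc1cccc2c1nc(-c1c(F)cccc1F)n2Cc1c(F)cccc1F`: 26.1 uM
- compound 2 `CC(=O)Nc1cccc2c1nc(-c1c(F)cccc1F)n2Cc1c(F)cccc1F`: 39.3 uM
- compound 3 `CNc1cccc2c1nc(-c1c(F)cccc1F)n2Cc1c(F)cccc1F`: 27.2 uM

Compound 3 at 27.2 uM lies within the scatter of both compound 1 and compound 2, so the three values in this assay give no order.

The next structure is compound 4 `N=C(NO)c1cccc2c1nc(-c1c(F)cccc1F)n2Cc1c(F)cccc1F`. The change from compound 3 is a group of 4 heavy atoms (1 carbon, 2 nitrogen, 1 oxygen; no ring) in place of a group of 2 heavy atoms (1 carbon, 1 nitrogen; no ring), on an aromatic carbon, on the same aromatic carbon where the measured compounds differ from one another.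

Among the compounds with values here, three measured steps bear on this carbon: a 1.0-fold higher number from compound 1 to compound 3 (0.02 log units; within the scatter), a 1.5-fold higher number from compound 1 to compound 2 (0.18 log units; within the scatter) and a 1.4-fold lower number from compound 2 to compound 3 (0.16 log units; within the scatter). All three are small and stay within the scatter. Within the data shown here, none of the measured compounds carries the entering group, and the data hold nothing on how it behaves, so this reading is only a loose guide.

No step beyond the scatter is expected in this assay, and no direction is expected either. The estimated change is a 1.1-fold higher number from compound 3 to compound 4 (0.04 log units; within the scatter) and is expected to stay small. For compound 4 the expected value is 30 uM, with an estimated range from 13 uM to 65 uM as its span.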

Compound 4, half-maximal toxic concentration: 23.1 uM
Beside the measured number, compound 4's estimate is 1.3-fold (0.11 log units) above it; the measured number falls inside the stated range.
By their numbers in this assay, from the lowest: compounds 4, 1, 3 and 2 (each within the scatter of the next).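

On this aromatic carbon, the entering group, with 3 hydrogen-bond donors, 2 hydrogen-bond acceptors and a double bond outside aromatic rings, produces no readable change in this assay: a 1.2-fold lower number from compound 3 to compound 4 (0.07 log units; within the scatter), a 1.1-fold lower number from compound 1 to compound 4 (0.05 log units; within the scatter) and a 1.7-fold lower number from compound 2 to compound 4 (0.23 log units; within the scatter). Ethyl, methylamino, acetamido and this larger group with more hydrogen-bond donors therefore all remain within the scatter of one another here, and the widest of the new steps, the one from the acetamido compound, does not leave it. No measurement at hand accounts for this flat reading.

Still open, on these data alone, is whether a carboxylic acid, a primary amine or a longer alkyl chain on this carbon would also stay within the scatter in this assay. The compounds shown differ only at this carbon, so they say nothing about changes elsewhere on the shared core.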